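Acetate pattern and cytotoxicity in a lactone series

The source may report more compounds than this note shows. Statements on the series, on what has been measured and on what is new or still open speak of the compounds shown alone.

Measured compounds in a functional assay on SK-MEL-2 cells (Homo sapiens) for cytotoxicity, read by sulforhodamine B assay, with a stated time of 72 h; on this read-out higher numbers stand for an effect only at larger amounts of compound and lower numbers for an effect already at smaller amounts:
- compound 1 `CCCC[C@@H](/C=C\[C@@H]1OC(=O)C=C[C@@H]1O)OC(C)=O`: 3.3 ug/mL
- compound 2 `CC(=O)O[C@H](/C=C\[C@H]1CC=CC(=O)O1)C[C@@H](OC(C)=O)[C@H](C)OC(C)=O`: 12.2 ug/mL
- compound 3 `CCCC[C@@H](/C=C\[C@@H]1OC(=O)C=C[C@@H]1OC(C)=O)OC(C)=O`: 0.7 ug/mL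

Compound 3 has the lowest number of the three in this assay; compound 1 is nearest and compound 2 furthest, both beyond the scatter. Among the compounds with values here, the one single-point step measured so far is a 4.7-fold lower number from compound 1 to compound 3 (0.67 log units; beyond the scatter), where an acetyl replaces a hydrogen on an oxygen on a saturated carbon.

Compound 4 `CCCC[C@H](O)/C=C\[C@@H]1OC(=O)C=C[C@@H]1OC(C)=O` differs from compound 3 by hydrogen in place of acetyl on an oxygen on a saturated carbon. Within the data shown here, no measured step covers this exact change; the only related information is the step from compound 1 to compound 3, which concerns the other oxygen on a saturated carbon and ran in the direction of a lower number when acetyl entered. Compound 4 carries one acetyl and one hydrogen on those two oxygens, as compound 1 does, so a number in the region of compound 1 is expected rather than one matching compound 3.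

For compound 4 in this assay the expected step is a 3.6-fold higher number from compound 3 to compound 4 (0.55 log units; beyond the scatter), a modest rise. The estimate for compound 4 is 2.5 ug/mL, within 0.8 ug/mL to 8 ug/mL.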

Compound 4, concentration for half-maximal effect: 2.2 ug/mL
Beside the measured number, compound 4's estimate is 1.1-fold (0.06 log units) above it; low and high end bracket the measured number.
By their numbers in this assay, from the lowest: compound 3; then compounds 4 and 1 (each within the scatter of the next); then compound 2.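

In this assay, the change from acetoxy to hydroxy on this oxygen on a saturated carbon gives a 3.1-fold higher number from compound 3 to compound 4 (0.50 log units; beyond the scatter), so the acetyl here counts for the read-out. Within the data shown here, until now, the only single-point evidence on acetyl concerned the other oxygen on a saturated carbon, with a 4.7-fold lower number from compound 1 to compound 3 (0.67 log units; beyond the scatter). Among compounds 1, 3 and 4, an acetyl on each of the two oxygens therefore goes with the lowest number, and neither oxygen alone accounts for it; compound 2 differs in more than one place and does not test this. No measurement bears on why these steps occur.

The compounds shown leave open how a form with hydrogen on both oxygens would read. Also open, as far as these compounds go, is whether a methyl ether or a benzoyl ester on this oxygen would behave as the acetyl does.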